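A few compounds are considered here, and "the series" means these few. Any claim that something is new, unique, unknown or untested is made for them only; others in the source may bear on it.

Of the compounds shown here, three built on one shared core have been measured in a functional assay on GTL 16 cells for antiproliferative activity against GTL 16 cell line (Homo sapiens), read by CCK-8 assay, with a stated time of 72 h; on this read-out lower numbers stand for stronger inhibition and higher numbers for weaker inhibition. Compound 1 `Cc1ccc(C(=O)Nc2cccc(-c3oc4cc(-c5ccc(F)cc5)ccc4c(=O)c3O)c2)cc1` gives 12900 nM. Compound 2 `COc1cccc(C(=O)Nc2cccc(-c3oc4cc(-c5ccc(F)cc5)ccc4c(=O)c3O)c2)c1` gives 12500 nM, and compound 3 `Cc1cccc(C(=O)Nc2cccc(-c3oc4cc(-c5ccc(F)cc5)ccc4c(=O)c3O)c2)c1` gives 10900 nM. Compound 3 carries the lowest of the three numbers, yet both of its neighbours sit within the scatter of it: the step of a 1.2-fold lower number from compound 1 to compound 3 (0.07 log units; within the scatter) and the step of a 1.1-fold lower number from compound 2 to compound 3 (0.06 log units; within the scatter) stay within the usual scatter, as does a 1.0-fold lower number from compound 1 to compound 2 (0.01 log units; within the scatter). So far, exchanging a 4-methylphenyl for a 3-methylphenyl or a 3-methoxyphenyl on the carbonyl carbon has changed nothing that can be told apart from repeat measurements.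

Compound 4 `O=C(Nc1cccc(-c2oc3cc(-c4ccc(F)cc4)ccc3c(=O)c2O)c1)c1ccc(Cl)nc1` has not yet been measured. It differs from compound 3 by 6-chloropyridin-3-yl in place of 3-methylphenyl on a carbonyl carbon. As far as these compounds go, the three measured steps all concern the same ring on the carbonyl carbon, and all were within the scatter; none of them places a ring nitrogen or a chlorine there, so those two features are untested here. On this basis the step of a 1.0-fold higher number from compound 3 to compound 4 (0.00 log units; within the scatter) is expected to be small, with no direction beyond the scatter. Compound 4 is therefore estimated at 11000 nM in this assay, with a range from 5000 nM to 25000 nM.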

Compound 4, half-maximal inhibitory concentration: 7520 nM
Compound 4: middle estimate off by 1.5-fold (0.17 log units), on the high side, and the stated range covers the measured number.
By their numbers in this assay, from the lowest: compounds 4, 3, 2 and 1 (each within the scatter of the next).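

Among these compounds, with 6-chloropyridin-3-yl, the ring on the carbonyl carbon now carries a ring nitrogen and a chlorine for the first time, yet in this assay the steps of a 1.4-fold lower number from compound 3 to compound 4 (0.16 log units; within the scatter) and a 1.7-fold lower number from compound 2 to compound 4 (0.22 log units; within the scatter) and a 1.7-fold lower number from compound 1 to compound 4 (0.23 log units; within the scatter) all leave compound 4 indistinguishable from the others. Among these four compounds, then, a carbon-only ring bearing methyl or methoxy and a ring with one hetero atom and one hydrogen-bond acceptor cannot be told apart at this position, so the two new features produce no change that exceeds repeat measurements. No further measurement is available to explain these numbers.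

The nitrogen and chlorine entered together. A plain pyridin-3-yl or a 4-chlorophenyl would be needed to show what each does alone. It also remains open whether a quite different group on this ring, such as an amine, a carboxylic acid or a longer chain, would move the number beyond the scatter, since every ring shown here carries only a single small substituent or none beyond the ring nitrogen and chlorine.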